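The compounds below may be only part of what the source reports. "The series", "measured", "known", "first", "only" and "open" are said of these compounds alone.

Measured in a functional assay on MGC-803 cells (Homo sapiens) for inhibition, read by sulforhodamine B assay; on this read-out higher numbers stand for weaker inhibition and lower numbers for stronger inhibition:
Compound 1 `O=C1C=C(NC2CCCC2)C(=O)c2c1nc1n2[C@H]2OC[C@@H](O)[C@H]2OC1`: > 8000 nM (a limit of the assay, not a number)
Compound 2 `Cc1ccc(NC2=CC(=O)c3nc4n(c3C2=O)[C@H]2OC[C@@H](O)[C@H]2OC4)cc1`: 1420 nM

Going by the values given here, compound 2 holds the only exact number so far. Compound 3 `O=C1C=C(Nc2ccc(I)cc2)C(=O)c2c1nc1n2[C@H]2OC[C@@H](O)[C@H]2OC1` differs from it by iodo in place of methyl on an aromatic carbon, with iodo in place of methyl on an aromatic carbon, para to a large group. Among the compounds with values here, the one measured step, an at least 5.6-fold lower number from compound 1 to compound 2 (0.75 log units; beyond the scatter), put 4-methylphenyl in place of cyclopentyl, and its size is bounded by the limit of > 8000 nM in this assay, at which 1 of the 2 values shown sits. Within the data shown here, that step swapped a whole group, while 4-methylphenyl to 4-iodophenyl keeps the ring, and no measured step tests this swap. The expected change is therefore small, a 1.2-fold lower number from compound 2 to compound 3 (0.07 log units; within the scatter), with no firm direction and nothing beyond the usual scatter. For compound 3 the estimate is 1200 nM, with an expected range of 400 nM to 4000 nM.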

Compound 3, half-maximal inhibitory concentration: 1400 nM
Compound 3: middle estimate off by 1.2-fold (0.07 log units), on the low side, within the range that was stated.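

In this assay iodo in place of methyl gives a 1.0-fold lower number from compound 2 to compound 3 (0.01 log units; within the scatter) and so makes no visible difference at this place, para to a large group. 4-Iodophenyl in place of cyclopentyl gives an at least 5.7-fold lower number from compound 1 to compound 3 (0.75 log units; beyond the scatter) and so shows that the advantage over cyclopentyl does not depend on the methyl group alone. The size of that step is only a bound: the limit of > 8000 nM in this assay, at which 1 of the 3 values shown sits.

The compounds shown leave open whether a different kind of group at this place, such as an amine or a carboxylic acid, would leave the number equally unchanged.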